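A few compounds are considered here, and "the series" means these few. Any claim that something is new, unique, unknown or untested is made for them only; others in the source may bear on it.

Measured in an ADME assay on L02 cells (Homo sapiens) for antiproliferative activity, read by MTT assay, with a stated time of 48 h; on this read-out lower numbers stand for stronger inhibition and higher numbers for weaker inhibition:
- compound 1 `CCN(CC)CCNC(=O)c1ccc(C(CC)(CC)c2ccc(OCCC(O)(CC)CC)c(C)c2)n1CC`: 2290 nM
- compound 2 `C#CC(C)OC(=O)c1ccc(C(CC)(CC)c2ccc(OCCC(O)(CC)CC)c(C)c2)n1CC`: > 50000 nM

Compound 2 gives no number on these data, and its > 50000 nM is a limit of this assay. Compound 3 `CCC(C)C(NC(=O)c1ccc(C(CC)(CC)c2ccc(OCCC(O)(CC)CC)c(C)c2)n1CC)C(=O)OC` has not yet been measured. The change is a group of 10 heavy atoms (7 carbon, 1 nitrogen, 2 oxygen; no ring) in place of a group of 5 heavy atoms (4 carbon, 1 oxygen; no ring), on a carbonyl carbon: a group of 10 heavy atoms in place of (1-methylprop-2-yn-1-yl)oxy, on a carbonyl carbon, with no net charge on either group.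

For the measured compounds named here, only one measured step bears on this place: an at least 21-fold higher number from compound 1 to compound 2 (1.33 log units; beyond the scatter). That step is large, but it ends on a limit, so its true size is open. It shows that a change on this carbonyl carbon can move the read-out strongly. It involves a different group, however, and gives no size for the present change. With so little to go on, a step of that scale is not expected here, and the number should remain high.

The expected change is an at least 1.6-fold lower number from compound 2 to compound 3 (0.22 log units; that floor lies within the scatter), a modest move to a lower number at most.

For compound 3 the estimate is 30000 nM, with an expected range of 8000 nM to 50000 nM.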

Compound 3, half-maximal inhibitory concentration: > 50000 nM
Compound 3: a limit, no number; the forecaster's own chance of this, stated with the estimate: 50%; at least 1.6-fold (0.22 log units) between middle value and limit.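

In this assay compound 3 gives > 50000 nM, a limit of the assay and not a number. With the amide-type nitrogen kept on the carbonyl carbon, exchanging only the group on that nitrogen gives an at least 21-fold higher number from compound 1 to compound 3 (1.33 log units; beyond the scatter). Compound 2 could not show this, since it replaced the nitrogen and its group together; compound 3 shows that the amide-type nitrogen alone does not keep the read-out as low as that of compound 1.

Going by these compounds, the step between compound 2 and compound 3 cannot be read, and neither compound can be ranked against the other, as the data give only: the limit of > 50000 nM in this assay, at which 2 of the 3 values shown sit. It remains open whether the read-out of compound 1 depends on the diethylamino group or on the chain that carries it, which a primary amine, a longer chain ending in diethylamino, or a carboxylic acid in place of the methyl ester of compound 3 would help to separate.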